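This account rests on a few compounds, and the source may have more. Where it says the series, first, only, none or still open, it means among the compounds named here.

Of the compounds shown here, three with a shared core have been tested in an ADME assay on CCRF-CEM cells (Homo sapiens) for cytotoxicity, with a stated time of 5 days; a higher number here means a weaker inhibitor, a lower number a stronger inhibitor. Compound 1 `C=CCNc1nc(N)nc2c1ncn2[C@H]1C[C@H](N=[N+]=[N-])[C@@H](CO)O1` gives > 100000 nM, which is a limit of the assay and not a number. Compound 2 `[N-]=[N+]=N[C@H]1C[C@H](n2cnc3c(NCCCCCO)nc(N)nc32)O[C@@H]1CO` gives > 100000 nM, also a limit. Compound 3 `[N-]=[N+]=N[C@H]1C[C@H](n2cnc3c(NCCO)nc(N)nc32)O[C@@H]1CO` gives > 100000 nM, again a limit, and that limit is all that is known of where compound 3 stands.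

The compound still unmeasured is compound 4 `C=CCN(C)c1nc(N)nc2c1ncn2[C@H]1C[C@H](N=[N+]=[N-])[C@@H](CO)O1`. It differs from compound 3 by allyl(methyl)amino in place of (2-hydroxyethyl)amino on an aromatic carbon.

Among the compounds with values here, three measured steps bear on this change. The closest is a step that the two limits leave unreadable from compound 1 to compound 3, as it too exchanges hydroxymethyl and vinyl at a chain end. The others are a step that the two limits leave unreadable from compound 1 to compound 2 and a step that the two limits leave unreadable from compound 2 to compound 3. None of the three has a readable size, so they offer no number to carry over. Within the data shown here, what they do show is the limit of > 100000 nM in this assay, at which 3 of the 3 values shown sit, and no tested compound goes against it.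

On that basis, no change beyond the usual scatter is expected in this assay, and no direction can be predicted. The expected step is a number no higher from compound 3 to compound 4 (the limit leaves the size open). For compound 4 the estimated value is 100000 nM, with an expected range from 40000 nM to 250000 nM.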

Compound 4, half-maximal inhibitory concentration: 27000 nM
For compound 4 the middle estimate is 3.7-fold (0.57 log units) above the measured one, and the stated range ends above it.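

In this assay, compound 4 is the only one of the four with a readable number, so the group on this aromatic carbon can shift the read-out from the limit to a measurable value. The smallest change is an at least 3.7-fold lower number from compound 1 to compound 4 (0.56 log units; beyond the scatter), which comes from methyl in place of hydrogen on the nitrogen alone, while the larger exchanges of the whole group give an at least 3.7-fold lower number from compound 3 to compound 4 (0.56 log units; beyond the scatter) and an at least 3.7-fold lower number from compound 2 to compound 4 (0.56 log units; beyond the scatter). The steps among compounds 1, 2 and 3 cannot be read, and the sizes of the new steps are open at one end, as compound 4 is the only one measured off the limit: the limit of > 100000 nM in this assay, at which 3 of the 4 values shown sit.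

The compounds shown leave open whether the methyl works the same way without the allyl group, which (2-hydroxyethyl)(methyl)amino or dimethylamino on the same carbon would test. They also leave open how much further the number would fall with a longer chain on this methylated nitrogen, such as butyl(methyl)amino.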